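A few compounds are considered here, and "the series" means these few. Any claim that something is new, unique, unknown or untested is made for them only; others in the source may bear on it.

Three compounds share one core and differ only in the aryl group on an amide-type nitrogen in a ring. Compound 1 `O=C1c2cc(COc3ccccc3)nn2CCN1c1cccc(F)c1` carries a 3-fluorophenyl there, compound 2 `O=C1c2cc(COc3ccccc3)nn2CCN1c1ccc(F)cc1` a 4-fluorophenyl and compound 3 `O=C1c2cc(COc3ccccc3)nn2CCN1c1ccc(F)cc1F` a 2,4-difluorophenyl. In a functional assay on HEK293 cells for positive allosteric modulation of metabotropic glutamate receptor 5 (Homo sapiens), read by calcium flux (on this read-out lower numbers stand for smaller maximal responses and higher numbers for larger maximal responses), compound 1 gives 81%, compound 2 gives 79% and compound 3 gives 101%. Compound 2 has the lowest of the three numbers, but compound 1 sits within the scatter of it: a number 2 percentage points lower from compound 1 to compound 2 (within the scatter). Compound 3 stands apart from both: a number 20 percentage points higher from compound 1 to compound 3 (beyond the scatter) and a number 22 percentage points higher from compound 2 to compound 3 (beyond the scatter).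

Compound 4 `O=C1c2cc(COc3ccccc3)nn2CCN1c1ccccn1` keeps the core of compound 2 and swaps the ring on that nitrogen for one that holds a hetero atom: pyridin-2-yl in place of 4-fluorophenyl on an amide-type nitrogen in a ring. Going by the values given here, none of the measured steps bears directly on this exchange; all three concern only how many fluorines sit on a carbon-only ring and where they stand, and the step that kept a single fluorine, a number 2 percentage points lower from compound 1 to compound 2 (within the scatter), stayed within the scatter. Among the compounds with values here, with no step showing what a ring nitrogen does here, the expectation for compound 4 in this assay is an estimated a number 1 percentage points higher from compound 2 to compound 4 (within the scatter), nothing beyond the scatter. The value of compound 4 in this assay is therefore estimated at 80%, between 60% and 100%.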

Compound 4, largest response reached (Emax), in percent of the reference or control that the assay uses: 69%
Estimate against measurement, compound 4: 11 percentage points above; measured number inside the range.
By their numbers in this assay, from the lowest: compounds 4, 2 and 1 (each within the scatter of the next, the first and the last beyond it); then compound 3.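

Going by these compounds alone, this is the first ring on this amide-type nitrogen that holds a hetero atom, and how the exchange reads depends on which fluorinated ring it is set against in this assay. Against the 4-fluorophenyl it gives a number 10 percentage points lower from compound 2 to compound 4 (within the scatter) and against the 3-fluorophenyl it gives a number 12 percentage points lower from compound 1 to compound 4 (beyond the scatter), so the pyridin-2-yl group sits at the edge of the scatter around these two single-fluorine compounds, even though compound 1 and compound 2 lie within the scatter of each other. The widest gap in the set appears against the 2,4-difluorophenyl, with a number 32 percentage points lower from compound 3 to compound 4 (beyond the scatter), so the ring with a nitrogen does not reach the level that only compound 3 shows.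

No measurement shown gives a reason for any of these differences. From the compounds shown here alone, it also stays open whether the ring nitrogen or the missing fluorine counts here, which a plain phenyl or a 5-fluoropyridin-2-yl group on this nitrogen could help separate, while a pyridin-3-yl group would test where the ring nitrogen stands.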